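A Bulky Ketone in Place of the Sulfonyl Group

The compounds below may be only part of what the source reports. "The series", "measured", "known", "first", "only" and "open" are said of these compounds alone.

Of the compounds shown here, three sharing one bicyclic core have been tested in an assay on isolated protein for inhibition of 3',5'-cyclic-AMP phosphodiesterase 4A (Cavia porcellus), read by cAMP accumulation, tested at 10 uM; a higher number here means a stronger effect of the compound at the concentration tested, a lower number a weaker effect. Compound 1 `O=C1CCCc2[nH]c(=O)c(C(=O)c3ccccc3)cc21` gives 0%, compound 2 `O=C1CCCc2[nH]c(=O)c(S(=O)(=O)c3ccccc3)cc21` gives 0%, and compound 3 `O=C1CC(c2ccccc2)Cc2[nH]c(=O)c(S(=O)(=O)c3ccccc3)cc21` gives 0%. Compound 3 stands level with compounds 1 and 2; none of the three shows a measurable effect. Within the data shown here, the one step that can be read directly, no change at the digits printed from compound 2 to compound 3 (within the scatter), adds a phenyl on a saturated ring carbon and leaves the read-out unchanged.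

Compound 4 `CC(C)(C)C(=O)c1cc2c([nH]c1=O)CC(c1ccccc1)CC2=O` keeps the phenyl of compound 3 and changes the other arm: (tert-butyl)carbonyl in place of phenylsulfonyl on an aromatic carbon. Among the measured compounds shown here, no measured step bears on this exact exchange. What the data do show is that compounds 1 and 2, which carry different groups at the same place on the core, are both inactive at the concentration tested, so neither a carbonyl-linked nor a sulfonyl-linked substituent there has produced any inhibition so far.

For the measured compounds named here, with no measured step supporting a gain, the expected step of a number 3 percentage points higher from compound 3 to compound 4 (within the scatter) is none beyond the scatter. Compound 4 is therefore estimated to give 3%, between 0% and 15% in this assay .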

Compound 4, a percentage reported as inhibition, at one concentration (the size of the read-out at that concentration, not a potency): 0.8%
The estimate for compound 4 lay 2.2 percentage points above the measured number; measured number inside the range.
By their numbers in this assay, from the lowest: compounds 1, 2, 3 and 4 (each within the scatter of the next).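

In this assay, putting (tert-butyl)carbonyl in place of phenylsulfonyl on this aromatic carbon gives a number 0.8 percentage points higher from compound 3 to compound 4 (within the scatter), so this exchange leaves the read-out where it was. Until now, each group at this place carried a six-membered aromatic ring of carbon only, whereas the group entering in compound 4 has no ring and fewer heavy atoms, and even this larger change in the group produces no inhibition beyond the scatter. Nothing available accounts for this lack of response, and the result gives no reason for it.

On these data alone, whether an amine or a carboxylic acid on this aromatic carbon, or a longer chain on the saturated ring carbon that carries the phenyl, would lift the read-out clear of the scatter remains open. All four compounds stand within the scatter of one another, so which part of the shared core, if any, could support inhibition at the concentration tested is still unanswered.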